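Replacing ethyl with bromo in a cytotoxic series

The source may report more compounds than this note shows. Statements on the series, on what has been measured and on what is new or still open speak of the compounds shown alone.

Values in a functional assay on PC-3 cells (Homo sapiens) for cytotoxicity, read by MTT assay, with a stated time of 72 h (on this read-out lower numbers stand for stronger inhibition and higher numbers for weaker inhibition), are these
compound 1 `CNC(=O)c1cc(Oc2ccc(NC(=O)c3cc(-c4ccc(Br)cc4)ncn3)cc2)ccn1` gives > 100000 nM as a limit
compound 2 `CNC(=O)c1cc(Oc2ccc(NC(=O)c3cc(-c4ccc(C(F)(F)F)cc4)ncn3)cc2F)ccn1` gives > 100000 nM as a limit
compound 3 `CCc1ccc(-c2cc(C(=O)Nc3ccc(Oc4ccnc(C(=O)NC)c4)c(F)c3)ncn2)cc1` gives 15600 nM as a number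

Among the compounds with values here, compound 3 at 15600 nM holds the only true number in the set. The other two results make up the limit of > 100000 nM in this assay, at which 2 of the 3 values shown sit, and are limits, not numbers.

Compound 4 `CNC(=O)c1cc(Oc2ccc(NC(=O)c3cc(-c4ccc(Br)cc4)ncn3)cc2F)ccn1` has yet to be measured in this assay and differs from compound 3 as follows: bromo in place of ethyl on an aromatic carbon with 4-ethylphenyl giving way to 4-bromophenyl, bromo in place of ethyl on an aromatic carbon, para to a large group.

Within the data shown here, the one measured step at this place is an at least 6.4-fold lower number from compound 2 to compound 3 (0.80 log units; beyond the scatter) and it came with ethyl in place of trifluoromethyl on an aromatic carbon. Compound 1 also carries 4-bromophenyl and gives > 100000 nM which is a limit of the assay. Going by an at least 6.4-fold lower number from compound 2 to compound 3 (0.80 log units; beyond the scatter) as the only guide, a move to a higher number, beyond the scatter and of smaller or similar size, is expected. The expected step is a 2.9-fold higher number from compound 3 to compound 4 (0.46 log units; beyond the scatter) as estimated here. For compound 4 the estimate is 45000 nM with a range from 14000 nM to 100000 nM and a real chance of only a limit.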

Compound 4, half-maximal inhibitory concentration: > 100000 nM
Compound 4 gave a limit, no number; the forecaster's own chance of this, stated with the estimate: 45%; at least 2.2-fold (0.34 log units) between middle value and limit.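

In this assay, bromo in place of ethyl gives an at least 6.4-fold higher number from compound 3 to compound 4 (0.80 log units; beyond the scatter), so the single-atom bromo does not keep the activity seen with the two-carbon ethyl at this place. Read with an at least 6.4-fold lower number from compound 2 to compound 3 (0.80 log units; beyond the scatter), this leaves ethyl as the only one of the three groups tried here on the fluorine-bearing core, ethyl, trifluoromethyl and bromo, that yields a number at all, since compound 2 and compound 4 both end at a limit. The steps from compound 1 and compound 2 to compound 4 cannot be read, and so the fluoro in place of hydrogen tells nothing in the 4-bromophenyl pair, because both ends of each step are limits: the limit of > 100000 nM in this assay, at which 3 of the 4 values shown sit.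

From the compounds shown here alone, what 4-ethylphenyl does with hydrogen in place of fluoro on the core stays open. Also open, going by these compounds, is whether a longer chain such as propyl, a methoxy or an amine at this place would bring the number lower than compound 3 reaches at 15600 nM, or would lose it as bromo does.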